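Swapping a Dichlorobenzyl for a Pyridyl Thiourea

This account rests on a few compounds, and the source may have more. Where it says the series, first, only, none or still open, it means among the compounds named here.

Of the compounds shown here, two have so far been tested in a functional assay on HeLa cells (Homo sapiens) for antiproliferative activity, with a stated time of 24 h; on this read-out higher numbers stand for weaker inhibition and lower numbers for stronger inhibition. Compound 1 `NC(=O)c1c(NC(=O)c2ccccc2Cl)sc2c1CCN(Cc1cc(Cl)cc(Cl)c1)C2` gives 19600 nM, the smaller of the two numbers, while compound 2 `NC(=O)c1c(NC(=O)c2ccccc2F)sc2c1CCN(Cc1ccc(Cl)cc1Cl)C2` gives 27500 nM in this assay. The gap between them lies within the usual scatter of such measurements, so the two cannot be told apart. Compound 3 `NC(=O)c1c(NC(=O)c2ccccc2Cl)sc2c1CCN(C(=S)Nc1cccnc1)C2` has not yet been measured. It differs from compound 1 in one place: a group of 9 heavy atoms (6 carbon, 2 nitrogen, 1 sulfur; one six-membered aromatic ring with 1 hetero atom) in place of a group of 9 heavy atoms (7 carbon, 2 chlorine; one six-membered aromatic ring of carbon only), on an amine nitrogen in a ring. Among the measured compounds shown here, no pair of measured compounds shows this change, so there is no measured step to lean on. For the measured compounds named here, the only guide is the number for compound 1, 19600 nM, and the fact that compound 2 stays in the same region. For that reason the expected step of a 1.0-fold higher number from compound 1 to compound 3 (0.01 log units; within the scatter) is taken as none beyond the scatter, in no particular direction, and the range is kept wide. The estimated value for compound 3 in this assay is 20000 nM, expected to fall between 5000 nM and 80000 nM.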

Compound 3, half-maximal inhibitory concentration: > 50000 nM
Compound 3: no number, only a limit; the forecaster's own chance of this, stated with the estimate: 10%; at least 2.5-fold (0.39 log units) between middle value and limit.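

In this assay compound 3 gives no number, only a limit of the assay: the limit of > 50000 nM in this assay, at which 1 of the 3 values shown sits.

As far as these compounds go, putting the pyridyl thiourea in place of the 3,5-dichlorobenzyl, on the amine nitrogen in a ring, gives an at least 2.5-fold higher number from compound 1 to compound 3 (0.40 log units; beyond the scatter), so inhibition is weaker by at least this much, and the true size of the step stays unknown. The two groups each have 9 heavy atoms and each hold a six-membered aromatic ring, so this position does not treat all groups of that size alike. The earlier compounds shown here both carry a dichlorobenzyl group on this nitrogen, so they could not show that replacing it with a different kind of group can cost activity in these cells.

The thiourea link and the pyridine ring enter together, so the compounds shown leave open which of the two goes with the weaker inhibition. A pyridylmethyl group on the same nitrogen would keep the ring and lose the thiourea, while a phenyl thiourea would keep the thiourea and lose the ring nitrogen, so either could begin to separate the two parts.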